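The source may report more compounds than this note shows. Statements on the series, on what has been measured and on what is new or still open speak of the compounds shown alone.

Measured compounds:
- compound 1, `COc1ccc(-c2ccc(-c3ccc(C(=N)N)cc3)s2)cc1`: 196 nM
- compound 2, `N=C(N)c1ccc(-c2ccc(-c3cc(Cl)cc(Cl)c3)s2)cc1`: 379 nM

Both compounds were tested in a functional assay on HT-29 cells (Homo sapiens) for inhibition, read by sulforhodamine B assay, with a stated time of 48 h; a higher number here means a weaker inhibitor of growth, a lower number a stronger inhibitor of growth. In this assay compound 1 gives 196 nM and compound 2 gives 379 nM. The two numbers are close; the gap between them lies within the usual scatter of repeated measurements, so neither compound can be called the stronger inhibitor of growth on these data, and compound 1 simply sits alongside compound 2 at the same level.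

The unmeasured compound 3, `N=C(N)c1ccc(-c2ccc(-c3ccc(F)cc3)s2)cc1`, shares the core of compound 1 and differs from it in one place: fluoro in place of methoxy on an aromatic carbon. The change sits on an aromatic carbon of a six-membered aromatic ring of carbon only, para to a large group. Among the measured compounds shown here, no comparison between measured compounds covers such a swap, so there is no measured step to lean on.

Given that compound 2, carrying a quite different substitution on the same ring, lands within the scatter of compound 1, the step from compound 1 to compound 3 is expected to be small, a 1.5-fold higher number from compound 1 to compound 3 (0.18 log units; within the scatter), and not clearly beyond the scatter. Compound 3 is therefore estimated at 300 nM, with a range from 120 nM to 750 nM.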

Compound 3, concentration for 50% growth inhibition: 323 nM
The estimate for compound 3 lay 1.1-fold (0.03 log units) below the measured number; measured number inside the range.
By their numbers in this assay, from the lowest: compounds 1, 3 and 2 (each within the scatter of the next).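

In this assay, among the compounds shown here, putting fluoro in place of methoxy on an aromatic carbon, para to a large group, gives the first measured step between compounds that differ in one place, a 1.6-fold higher number from compound 1 to compound 3 (0.22 log units; within the scatter), and that step lies within the usual scatter. At this position, the two groups therefore cannot be told apart on growth inhibition, even though the change replaces two heavy atoms with one and removes a hydrogen-bond acceptor, so neither the oxygen nor the extra carbon of methoxy is shown to be needed for this level of inhibition. No measurement on these compounds offers an explanation for this result.

The compounds shown leave open whether the same position would hold this level with groups of a different kind, such as an amine, a carboxylic acid or a longer chain like butoxy, or with plain hydrogen and no substituent at all. As far as these compounds go, a single swap at one position also cannot establish a general pattern, so it remains unknown how far this position can be changed before the growth inhibition shifts beyond the scatter.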